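Replacing the piperidin-1-yl side chain of compound 2

The source may hold more compounds than are shown below. What is called first, only, known or untested is meant among the compounds shown, and "the series" means these compounds.

Measured so far:
compound 1 `O=C1c2c[n+]([O-])c3ccccc3c2C(=O)c2c1c1ccccc1n2CCCCN1CCCCC1` gives 230 nM
compound 2 `O=C1c2c[n+]([O-])c3ccccc3c2C(=O)c2c1c1ccccc1n2CCN1CCCCC1` gives 1860 nM

Both numbers come from a functional assay on SH-SY5Y cells (Homo sapiens) for cytotoxicity, read by MTT assay, with a stated time of 72 h (on this read-out higher numbers stand for weaker inhibition and lower numbers for stronger inhibition), and compound 2 holds the higher of the two. Within the data shown here, the only measured step is an 8.1-fold higher number from compound 1 to compound 2 (0.91 log units; beyond the scatter) and it keeps the piperidin-1-yl group while shortening the chain that carries it. The next case is compound 3 `O=C1c2c[n+]([O-])c3ccccc3c2C(=O)c2c1c1ccccc1n2Cc1cn(C[C@@H](O)CO)nn1` and its difference from compound 2 is 1-(2,3-dihydroxypropyl)-1H-1,2,3-triazol-4-yl in place of (piperidin-1-yl)methyl on a saturated chain carbon bound to an aromatic nitrogen in the words of the series: 1-(2,3-dihydroxypropyl)-1H-1,2,3-triazol-4-yl in place of (piperidin-1-yl)methyl on a saturated chain carbon bound to an aromatic nitrogen. Among the measured compounds shown here, no measured step covers the loss of the piperidin-1-yl group, so the one step from compound 1 serves only as a rough yardstick of size, and the direction is weakly supported. A step smaller than that yardstick, toward a higher number, is expected, and it is estimated as a 2.2-fold higher number from compound 2 to compound 3 (0.33 log units; beyond the scatter) in this assay with wide uncertainty. For compound 3 the estimated value is 4000 nM with an expected range from 900 nM to 15000 nM.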

Compound 3, half-maximal inhibitory concentration: > 500 nM
Compound 3: a limit, no number (the forecaster's own chance of this, stated with the estimate: 10%); the middle value does not contradict the limit.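

Compound 3 carries a limit and not a number in this assay: the limit of > 500 nM in this assay, at which 1 of the 3 values shown sits. The step from compound 2 cannot be read, so the data do not place 1-(2,3-dihydroxypropyl)-1H-1,2,3-triazol-4-yl relative to (piperidin-1-yl)methyl in either direction at this position, on a saturated chain carbon bound to an aromatic nitrogen. The one readable comparison is with the 3-(piperidin-1-yl)propyl chain, which gives an at least 2.1-fold higher number from compound 1 to compound 3 (0.33 log units; beyond the scatter); until now the series showed only a change in chain length with the piperidin-1-yl group kept, whereas this step shows that a replacement without that group also ends on the higher-number side of the longest chain shown.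

The compounds shown leave open how far the true value of compound 3 lies beyond its limit, and whether the step follows the loss of the piperidin-1-yl group, the triazole ring or the 2,3-dihydroxypropyl group. A triazole bearing a 2-(piperidin-1-yl)ethyl group in place of the 2,3-dihydroxypropyl group would separate these contributions.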